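Swapping a pyridinyl for phenyl on a shared pyridine core

The source may hold more compounds than are shown below. What is called first, only, known or untested is meant among the compounds shown, and "the series" means these compounds.

Measured so far:
compound 1 `Oc1ccc(-c2cc(-c3cccc(Cl)c3)nc(-c3cccs3)c2)cc1` — 5050 nM
compound 2 `Oc1ccc(-c2cc(-c3ccncc3)nc(-c3cccc(Cl)c3)c2)cc1` — "not determined" (no result reported)

In a functional assay on HCT-15 cells (Homo sapiens) for cytotoxicity, read by CCK-8 assay and cell counting, with a stated time of 2 days (a lower number here means a stronger inhibitor, a higher number a weaker inhibitor), compound 1 gives 5050 nM. For compound 2 the same assay records "not determined" (no result reported), so compound 2 stands on no number of its own. Compound 3 `Oc1ccc(-c2cc(-c3ccccc3)nc(-c3cccc(Cl)c3)c2)cc1` has not yet been tested. Compound 3 differs from compound 2 by phenyl in place of pyridin-4-yl on an aromatic carbon. Compound 3 shares its 3-chlorophenyl and 4-hydroxyphenyl groups with compound 1, which gives the only anchor here. Among the measured compounds shown here, no step between compound 2 and compound 3 can be sized from the data. Compound 3 is therefore expected near compound 1, at an estimated 5000 nM with a range of 1500 nM to 16000 nM.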

Compound 3, half-maximal inhibitory concentration: 6100 nM
The estimate for compound 3 lay 1.2-fold (0.09 log units) below the measured number, and the stated range covers the measured number.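

In this assay, among the compounds shown here, phenyl in place of thiophen-2-yl on this aromatic carbon gives a 1.2-fold higher number from compound 1 to compound 3 (0.08 log units; within the scatter), the first step that can be read at this position, and it shows that this exchange of one aromatic ring for another leaves the number unchanged within the scatter. On these data alone, the step from compound 2 to compound 3 cannot be read, so the effect of the ring nitrogen of pyridin-4-yl remains unknown. No evidence here bears on this result. Still open, as far as these compounds go, is whether an amine, a carboxylic acid or a longer alkyl chain at this position would move the number in this assay.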